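Acyl group change from compound 3 to compound 4

A few compounds are considered here, and "the series" means these few. Any claim that something is new, unique, unknown or untested is made for them only; others in the source may bear on it.

In a functional assay on COR-L23 cells (Homo sapiens) for antiproliferative activity, read by CellTiter-Glo, with a stated time of 4 days (on this read-out higher numbers stand for weaker inhibition and lower numbers for stronger inhibition), compound 1 `O=C(CCc1cccnc1)Nc1ccc(CN2C(=O)c3ccccc3C2=O)cc1` gives > 10000 nM as a limit of the assay and not a number. Compound 2 `CCC(=O)N[C@@H](C)c1ccc(NC(=O)[C@H]2C[C@@H]2c2cccnc2)cc1` gives 22 nM and compound 3 `C[C@H](NC(=O)C1CCOCC1)c1ccc(NC(=O)[C@H]2C[C@@H]2c2cccnc2)cc1` gives 7 nM as the lowest number of the series. Compound 4 `C[C@H](NC(=O)[C@@H]1CCCN1C)c1ccc(NC(=O)[C@H]2C[C@@H]2c2cccnc2)cc1` differs from compound 3 in one group: 1-methylpyrrolidin-2-yl in place of oxan-4-yl on a carbonyl carbon with 1-methylpyrrolidin-2-yl in place of oxan-4-yl on a carbonyl carbon. Going by the values given here, the one measured step at this place is a 3.1-fold lower number from compound 2 to compound 3 (0.50 log units; beyond the scatter) on going from ethyl to oxan-4-yl and it is modest. A smaller step toward a higher number is expected, probably within the scatter. The estimated change in this assay is a 1.7-fold higher number from compound 3 to compound 4 (0.23 log units; within the scatter) on that basis. Compound 4 is estimated at 12 nM with a range of 4 nM to 40 nM as the expected span.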

Compound 4, half-maximal inhibitory concentration: 11 nM
For compound 4 the middle estimate is 1.1-fold (0.04 log units) above the measured one, within the range that was stated.
By their numbers in this assay, from the lowest: compounds 3, 4 and 2 (each within the scatter of the next, the first and the last beyond it). At a limit, above all of these: compound 1.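

In this assay, the carbonyl carbon accepts 1-methylpyrrolidin-2-yl as well as oxan-4-yl, with a 1.6-fold higher number from compound 3 to compound 4 (0.20 log units; within the scatter) as the step, so the change of ring size and hetero atom leaves the number within the scatter. Against ethyl the new group gives a 2.0-fold lower number from compound 2 to compound 4 (0.30 log units; within the scatter), which also lies within the scatter, unlike the step to oxan-4-yl, a 3.1-fold lower number from compound 2 to compound 3 (0.50 log units; beyond the scatter). No measurement shown here explains these steps. Open, as far as these compounds go, is how an open-chain amine or a carboxylic acid would fare on this carbonyl carbon. Also open, from the compounds shown here alone, is the mirror-image form of the 1-methylpyrrolidin-2-yl group.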